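Carboxymethyl to 2-cyanoethyl on the shared core

A few compounds are considered here, and "the series" means these few. Any claim that something is new, unique, unknown or untested is made for them only; others in the source may bear on it.

Among the compounds with values here, the series so far is flat in a functional assay on T47D cells (Homo sapiens) for cytotoxicity, read by colorimetric assay and MTT assay; on this read-out higher numbers stand for weaker inhibition and lower numbers for stronger inhibition. Compound 1 `CCOC(=O)Cn1c(=O)c(-c2ccc(OC)cc2)cc2c(OC)cc(OC)cc21` gives 10000 nM. Compound 2 `COc1ccc(-c2cc3c(OC)cc(OC)cc3n(CC#N)c2=O)cc1` gives 10000 nM. Compound 3 `COc1ccc(-c2cc3c(OC)cc(OC)cc3n(CC(=O)O)c2=O)cc1` gives 10000 nM, which places it level with compounds 1 and 2.

The next structure, compound 4 `COc1ccc(-c2cc3c(OC)cc(OC)cc3n(CCC#N)c2=O)cc1`, departs from compound 3 at one place, on a saturated chain carbon bound to an aromatic nitrogen: cyanomethyl in place of carboxy on a saturated chain carbon bound to an aromatic nitrogen. In words, this is cyanomethyl in place of carboxy. Cut one bond further out, the same difference reads carboxymethyl to 2-cyanoethyl.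

Within the data shown here, three measured steps bear on this change. The closest is carboxy in place of cyano on that same carbon, with no change at the digits printed from compound 2 to compound 3 (within the scatter). Cyano in place of ethoxycarbonyl there gave no change at the digits printed from compound 1 to compound 2 (within the scatter), and the change from the ethyl ester to the free carboxy gave no change at the digits printed from compound 1 to compound 3 (within the scatter). Among the measured compounds shown here, no measured compound carries the 2-cyanoethyl group, so that exact chain remains untested. With all three steps flat, no shift beyond the scatter is expected in this assay, in either direction. The expected result is no change at the digits printed from compound 3 to compound 4 (within the scatter). For compound 4 the estimate is 10000 nM, with an expected range of 5000 nM to 20000 nM.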

Compound 4, half-maximal inhibitory concentration: 10000 nM
Compound 4: the middle estimate sits on the measured number at the digits printed; measured number inside the range.
By their numbers in this assay, from the lowest: compounds 1, 2, 3 and 4 (each within the scatter of the next).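

Compound 4 puts the nitrile on a 2-cyanoethyl chain, and in this assay carboxymethyl to 2-cyanoethyl gives no change at the digits printed from compound 3 to compound 4 (within the scatter) even though the step takes the hydrogen-bond donors of the group from 1 to 0. The same chain set against the shorter nitrile gives no change at the digits printed from compound 2 to compound 4 (within the scatter) and set against the ethyl ester gives no change at the digits printed from compound 1 to compound 4 (within the scatter), so at this place, on a saturated chain carbon bound to an aromatic nitrogen, the read-out does not separate 2-cyanoethyl from any of the three earlier groups. No supporting measurement accounts for this sameness across the four compounds.

The compounds shown leave open whether any group at this place can move the number at all, for example an amine, a primary amide or a longer chain ending in a nitrile. Going by these compounds, all four also keep the methoxy groups of the shared core, so what a hydroxy group or a fluorine in place of one of those methoxy groups would do in this assay remains open as well.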